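This account rests on a few compounds, and the source may have more. Where it says the series, first, only, none or still open, it means among the compounds named here.

Working notes on the series built from compound 1 `Cn1c(=O)c(=O)n(C2CCCC2)c2nc(N/N=C/c3ccccc3)ncc21`, compound 2 `Cn1c(=O)c(=O)n(C2CCCC2)c2nc(N/N=C/c3ccc(Cl)cc3)ncc21`, compound 3 `Cc1cc(C)c(/C=N/Nc2ncc3c(n2)n(C2CCCC2)c(=O)c(=O)n3C)c(C)c1` and the still unmeasured compound 4 `Cn1c(=O)c(=O)n(C2CCCC2)c2nc(N/N=C/c3ccc(F)cc3Cl)ncc21`. In a functional assay on A549 cells (Homo sapiens) for antiproliferative activity, read by MTT assay (on this read-out lower numbers stand for stronger inhibition and higher numbers for weaker inhibition), compound 1 returns only a limit, > 100000 nM, so its true standing on the numbers is open. Compound 2 gives 6890 nM in this assay, and compound 3 gives 12000 nM. The step of an at least 14-fold lower number from compound 1 to compound 2 (1.16 log units; beyond the scatter) and the step of an at least 8.3-fold lower number from compound 1 to compound 3 (0.92 log units; beyond the scatter) point the same way, whereas a 1.7-fold higher number from compound 2 to compound 3 (0.24 log units; within the scatter) separates the two substituted analogues by nothing that can be read.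

Compound 4 differs from compound 1 in one place: 2-chloro-4-fluorophenyl in place of phenyl on a carbon with a double bond to nitrogen. Among the compounds with values here, the steps that bear on this are the two that start from compound 1, both beginning at the limit of > 100000 nM in this assay, at which 1 of the 3 values shown sits. Chloro in place of hydrogen on an aromatic carbon gave the large at least 14-fold lower number from compound 1 to compound 2 (1.16 log units; beyond the scatter), and 2,4,6-trimethylphenyl in place of phenyl gave an at least 8.3-fold lower number from compound 1 to compound 3 (0.92 log units; beyond the scatter). Given an at least 14-fold lower number from compound 1 to compound 2 (1.16 log units; beyond the scatter) and an at least 8.3-fold lower number from compound 1 to compound 3 (0.92 log units; beyond the scatter), a step of comparable size in the same direction is expected for compound 4, roughly an at least 12-fold lower number from compound 1 to compound 4 (1.09 log units; beyond the scatter). For compound 4 in this assay the estimate is 8000 nM, expected to lie between 3000 nM and 30000 nM.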

Compound 4, half-maximal inhibitory concentration: 11000 nM
The estimate for compound 4 lay 1.4-fold (0.14 log units) below the measured number, and the stated range covers the measured number.
By their numbers in this assay, from the lowest: compounds 2, 4 and 3 (each within the scatter of the next). At a limit, above all of these: compound 1.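

The change from phenyl to 2-chloro-4-fluorophenyl on a carbon with a double bond to nitrogen gives, in this assay, an at least 9.0-fold lower number from compound 1 to compound 4 (0.95 log units; beyond the scatter), and this is a bound rather than a measured size: the limit of > 100000 nM in this assay, at which 1 of the 4 values shown sits.

The new group cannot be told apart from the two earlier substituted phenyl groups, with a 1.6-fold higher number from compound 2 to compound 4 (0.20 log units; within the scatter) and a 1.1-fold lower number from compound 3 to compound 4 (0.04 log units; within the scatter). Within the data shown here, at this place, three differently substituted phenyl groups now stand clear of the plain phenyl of compound 1, yet this assay gives no ranking among them, and the second halogen of compound 4 yields no reading beyond the single chloro of compound 2.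

From the compounds shown here alone, it remains open how a phenyl carrying an amine or a carboxylic acid, or a longer chain in place of the ring, would read at this place. Going by these compounds, how far compound 1 truly lies from the three substituted analogues also stays open.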